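A few compounds are considered here, and "the series" means these few. Any claim that something is new, unique, unknown or untested is made for them only; others in the source may bear on it.

Compound 1 `CCC/N=C1\S/C(=C\c2ccc(O)c(Cl)c2)C(=O)N1C1CCN(C)C(=O)C1` reads > 250000 nM in a physicochemical assay for solubility, measured as kinetic solubility (on this read-out lower numbers stand for lower solubility and higher numbers for higher solubility), which is a limit of the assay and not a number. Compound 3 `CCC/N=C1\S/C(=C\c2ccc(O)c(C(C)C)c2)C(=O)N1c1ccccc1C` gives 79000 nM, and compound 2 `CCC/N=C1\S/C(=C\c2ccc(O)c(Cl)c2)C(=O)N1C(C)C` gives 20000 nM, the lower of these two numbers. Compound 4 `CCC/N=C1\S/C(=C\c2ccc(O)c(Cl)c2)C(=O)N1C1CC1` changes one group of compound 2: cyclopropyl in place of isopropyl on an amide-type nitrogen in a ring. Among the compounds with values here, the only measured step at this place is an at least 12-fold lower number from compound 1 to compound 2 (1.09 log units; beyond the scatter), a large one, with isopropyl replacing 1-methyl-2-oxopiperidin-4-yl. That exchange is of a different kind, since isopropyl and cyclopropyl are both carbon only, so it says little here. In this assay, no step beyond the scatter is therefore expected, and the expected step is a 1.3-fold higher number from compound 2 to compound 4 (0.10 log units; within the scatter). The estimate for compound 4 is 25000 nM, within a range of 10000 nM to 60000 nM.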

Compound 4, solubility: 79000 nM
For compound 4 the middle estimate is 3.2-fold (0.50 log units) below the measured one; the measured number lies above the stated range.
By their numbers in this assay, from the lowest: compound 2; then compounds 3 and 4 (each within the scatter of the next). At a limit, above all of these: compound 1.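

In this assay, this position proved sensitive even to a swap between two carbon-only groups with 3 heavy atoms each, as the step of a 4.0-fold higher number from compound 2 to compound 4 (0.60 log units; beyond the scatter) shows. Earlier, only an exchange of very different groups had been seen here, whereas an at least 3.1-fold lower number from compound 1 to compound 4 (0.50 log units; beyond the scatter) shows that the lactam-bearing group still gives the higher reading. Compound 1 stands at a limit and not at a number: the limit of > 250000 nM in this assay, at which 1 of the 4 values shown sits. As far as these compounds go, how a cyclobutyl ring, a longer chain or an amine would read at this nitrogen remains open.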